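Working notes: 4-chlorobenzyl to 3-methoxybenzyl

The source may report more compounds than this note shows. Statements on the series, on what has been measured and on what is new or still open speak of the compounds shown alone.

In a functional assay on LNCaP cells (Homo sapiens) for cytotoxicity, read by MTT assay (a lower number here means a stronger inhibitor, a higher number a weaker inhibitor), compound 1 (`COc1ccc2cc([C@H](C)c3nnc(SCc4ccc(Cl)cc4)n3-c3ccc(F)cc3)ccc2c1`) reads > 400000 nM as a limit of the assay, not a number. Compound 2 (`COc1ccc2cc([C@H](C)c3n[nH]c(=S)n3-c3cccc(Cl)c3)ccc2c1`) is entered as "not determined" (no result reported) and offers no comparison. Compound 3 (`COc1cccc(CSc2nnc([C@@H](C)c3ccc4cc(OC)ccc4c3)n2-c2ccc(F)cc2)c1`) carries 3-methoxyphenyl in place of 4-chlorophenyl on a saturated chain carbon bound to a sulfur. Going by the values given here, no measured step in this assay calibrates this change. The expected at least 2.0-fold lower number from compound 1 to compound 3 (0.30 log units; that floor lies within the scatter) is modest and towards a stronger inhibitor, and it may not clear the scatter. In this assay compound 3 is estimated at 200000 nM (expected range 40000 nM to 400000 nM).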

Compound 3, half-maximal inhibitory concentration: 14500 nM
Compound 3: middle estimate off by 14-fold (1.14 log units), on the high side; the whole stated range lies above it.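

In this assay, this position on the saturated chain carbon bound to a sulfur proves able to change the read-out: 3-methoxyphenyl in place of 4-chlorophenyl gives an at least 27-fold lower number from compound 1 to compound 3 (1.44 log units; beyond the scatter). Going by these compounds alone, compound 3 is also the only compound here with a single number. Compound 1 gives > 400000 nM, a limit of the assay and not a number, so the step is a minimum only: the limit of > 400000 nM in this assay, at which 1 of the 3 values shown sits.

The shares of losing 4-chlorophenyl and gaining 3-methoxyphenyl remain unseparated. Also open, from the compounds shown here alone, is whether an amine or a carboxylic acid on this phenyl, or a longer chain to the sulfur, would keep this level.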